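From compound 1 to compound 3 in the cyclobutyl series

A few compounds are considered here, and "the series" means these few. Any claim that something is new, unique, unknown or untested is made for them only; others in the source may bear on it.

Going by the values given here, in a functional assay on the whole organism with Rattus norvegicus as the target (a lower number here means that less compound is needed, a higher number that more compound is needed for the effect), compound 1 (`COC(=O)CC/C=C\CC[C@H]1C(=O)C[C@@H](O)[C@@H]1/C=C/CC(C)(O)CCC1CCC1`) gives 0.316 mg/kg, the lower of the two numbers so far, and compound 2 (`COC(=O)CC/C=C\CC[C@H]1C(=O)C[C@@H](O)[C@@H]1/C=C/CC(C)(O)CCC1=CCCC1`) gives 1.18 mg/kg. Compound 3 (`COC(=O)CC/C=C\CC[C@H]1C(=O)C[C@@H](O)[C@@H]1/C=C/C[C@@](C)(O)/C=C/C1CCC1`) is not yet measured. Its change from compound 1 is 3-cyclobutyl-1-hydroxy-1-methylprop-2-en-1-yl in place of 3-cyclobutyl-1-hydroxy-1-methylpropyl on a saturated chain carbon bound to a double-bonded chain carbon, on a saturated chain carbon bound to a double-bonded chain carbon. Among the compounds with values here, the only measured step bearing on this, a 3.7-fold higher number from compound 1 to compound 2 (0.57 log units; beyond the scatter), is modest and involves a different group change. A modest move to a higher number in this assay is therefore expected, though on thin evidence. The expected step is a 1.9-fold higher number from compound 1 to compound 3 (0.28 log units; within the scatter). For compound 3 the estimate is 0.6 mg/kg, with an expected range of 0.15 mg/kg to 2.4 mg/kg.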

Compound 3, dose for half-maximal effect: 0.53 mg/kg
Beside the measured number, compound 3's estimate is 1.1-fold (0.05 log units) above it; the range from low to high includes it.
By their numbers in this assay, from the lowest: compounds 1 and 3 (each within the scatter of the next); then compound 2.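

In this assay, the step of a 1.7-fold higher number from compound 1 to compound 3 (0.22 log units; within the scatter) shows that 3-cyclobutyl-1-hydroxy-1-methylprop-2-en-1-yl can replace the saturated 3-cyclobutyl-1-hydroxy-1-methylpropyl at this place, with its added double bond and defined stereocentre, and the result stays within the scatter. The step of a 2.2-fold lower number from compound 2 to compound 3 (0.35 log units; beyond the scatter) changes the ring and the chain together, so neither change alone can be credited with it. No measurement available here accounts for these numbers. Going by these compounds, it remains open whether a cyclohexyl or phenyl group in place of cyclobutyl would keep the number close to that of compound 1.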